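From 4-nitrobenzyl to 3-bromobenzyl on a shared core

The source may report more compounds than this note shows. Statements on the series, on what has been measured and on what is new or still open speak of the compounds shown alone.

Compound 1 `C=CCOc1ccc2c(=O)c(-c3cc(OC)c(OC)cc3OC)coc2c1`: 5100 nM
Compound 2 `COc1cc(OC)c(-c2coc3cc(OCc4ccccc4C)ccc3c2=O)cc1OC`: 2150 nM
Compound 3 `COc1cc(OC)c(-c2coc3cc(OCc4ccc([N+](=O)[O-])cc4)ccc3c2=O)cc1OC`: > 10000 nM

All three values come from a functional assay on B16 cells (Mus musculus) for antiproliferative activity, read by MTT assay, with a stated time of 24 h; on this read-out higher numbers stand for weaker inhibition and lower numbers for stronger inhibition. Compound 3 stands at > 10000 nM, which is a limit of the assay and not a number.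

Compound 4 `COc1cc(OC)c(-c2coc3cc(OCc4cccc(Br)c4)ccc3c2=O)cc1OC` has not yet been measured. It carries 3-bromobenzyl where compound 3 carries 4-nitrobenzyl, on a saturated chain carbon bound to an oxygen on an aromatic ring: 3-bromophenyl in place of 4-nitrophenyl on a saturated chain carbon bound to an oxygen on an aromatic ring.

Three measured steps at this same place bear on the change. The closest guide is an at least 4.6-fold higher number from compound 2 to compound 3 (0.66 log units; beyond the scatter), since it also exchanges one substituted phenyl group for another. Next comes an at least 1.9-fold higher number from compound 1 to compound 3 (0.29 log units; that floor lies within the scatter), whose floor stays within the scatter, and a 2.4-fold lower number from compound 1 to compound 2 (0.38 log units; beyond the scatter) shows that this place can move the number in either direction. Neither compound 1 nor compound 2 carries 3-bromophenyl, so the direction is an expectation by analogy only.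

In this assay, a step toward a lower number is therefore expected, of modest size, leading back to the range of the measured compounds. The estimated change is an at least 2.8-fold lower number from compound 3 to compound 4 (0.45 log units; beyond the scatter). For compound 4 the expected value is 3500 nM, with an estimated range from 1300 nM to 9500 nM.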

Compound 4, half-maximal inhibitory concentration: 4400 nM
Beside the measured number, compound 4's estimate is 1.3-fold (0.10 log units) below it; the range from low to high includes it.
By their numbers in this assay, from the lowest: compound 2; then compounds 4 and 1 (each within the scatter of the next). At a limit, above all of these: compound 3.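

The exchange of 4-nitrophenyl for 3-bromophenyl on this saturated chain carbon gives an at least 2.2-fold lower number from compound 3 to compound 4 (0.35 log units; beyond the scatter) in this assay, so a substituted phenyl group at this place does not in itself hold the number at the top of the series. That size is only a floor, because the value of compound 3 is a limit of the assay and not a number: the limit of > 10000 nM in this assay, at which 1 of the 4 values shown sits. Measured against the groups with real numbers, 3-bromophenyl gives a 2.0-fold higher number from compound 2 to compound 4 (0.31 log units; beyond the scatter), so it does not reach what 2-methylphenyl gives, while a 1.2-fold lower number from compound 1 to compound 4 (0.06 log units; within the scatter) shows that it cannot be told apart from vinyl here, and compound 2 keeps the lowest number of the four.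

As far as these compounds go, what 4-bromobenzyl or 3-nitrobenzyl would give on the shared core stays open, so the kind of substituent and its place on the ring cannot yet be separated. The compounds shown also leave open what an amine or a carboxylic acid on the benzyl ring, or a longer chain in place of the benzyl group, would do at this position.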